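Cyclic amine in place of bromo: outlook for compound 3

The source may report more compounds than this note shows. Statements on the series, on what has been measured and on what is new or still open speak of the compounds shown alone.

Measured so far:
compound 1 `O=C(/C=C/c1ccc([N+](=O)[O-])o1)c1ccc(Br)cc1` — 21400 nM
compound 2 `O=C(/C=C/c1ccc([N+](=O)[O-])o1)c1ccc(N2CCCC2)cc1` — 35900 nM

In a functional assay on U-251 cells (Homo sapiens) for inhibition, read by sulforhodamine B assay, with a stated time of 72 h (a lower number here means that less compound is needed, a higher number that more compound is needed for the effect), compound 1 gives 21400 nM, the lower of the two numbers shown, although its gap to compound 2 lies within the scatter. Compound 3 `O=C(/C=C/c1ccc([N+](=O)[O-])o1)c1ccc(N2CCCCC2)cc1` differs from compound 1 by piperidin-1-yl in place of bromo on an aromatic carbon. Among the compounds with values here, the one step that bears on this is a 1.7-fold higher number from compound 1 to compound 2 (0.22 log units; within the scatter), where a five-membered ring amine entered at the same place and the number barely moved. A six-membered ring amine entering there is therefore expected to behave alike, with a 1.4-fold higher number from compound 1 to compound 3 (0.15 log units; within the scatter) and no change beyond the scatter. Compound 3 is thus estimated at 30000 nM, within 12000 nM to 75000 nM.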

Compound 3, half-maximal effective concentration: > 50000 nM
Compound 3: a limit, no number; the forecaster's own chance of this, stated with the estimate: 10%; middle value at least 1.6-fold (0.22 log units) from the limit.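

In this assay compound 3 stands at a limit, not a number: the limit of > 50000 nM in this assay, at which 1 of the 3 values shown sits. Within the data shown here, on this aromatic carbon, para to a large group, replacing bromo with piperidin-1-yl gives an at least 2.3-fold higher number from compound 1 to compound 3 (0.36 log units; beyond the scatter), the first step at this position that goes beyond the scatter. Exchanging pyrrolidin-1-yl for piperidin-1-yl gives an at least 1.3-fold higher number from compound 2 to compound 3 (0.14 log units; that floor lies within the scatter), so the two ring amines are not separated.

Going by these compounds, how far compound 3 lies past its limit remains open. Also open, on these data alone, is whether a morpholine ring or a dimethylamino group here would stay within the scatter of compound 1.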